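Hydrazide series, cytotoxicity: from compound 3 to compound 4

A few compounds are considered here, and "the series" means these few. Any claim that something is new, unique, unknown or untested is made for them only; others in the source may bear on it.

Three compounds of the series carry an entry in an ADME assay on MDCK cells (Canis lupus familiaris) for cytotoxicity, read by MTT assay, with a stated time of 48 h; on this read-out higher numbers stand for lower toxicity in this test and lower numbers for higher toxicity in this test. Compound 1 `CC1(C)[C@@H]2CC[C@@]1(C)/C(=N/NC(=O)C(F)(F)F)C2` gives only a limit in this assay, > 1070000 nM, and not a number. Compound 3 `CC1(C)[C@@H]2CC[C@@]1(C)/C(=N/NC(=O)c1ccc(Br)cc1)C2` likewise gives only a limit in this assay, > 822000 nM. For compound 2 `CC12C=CC3(O1)C(C(=O)N1CCSC13)C2C(=O)N/N=C1\C[C@H]2CC[C@]1(C)C2(C)C` the entry in this assay reads "not determined" (no result reported), so no number stands against it. Among the compounds with values here, compound 3 therefore stands at a limit of the assay, compound 1 stands at a limit too, and the third entry holds no number at all; no compound of the series has a measured concentration here.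

Within the data shown here, the one step between measured compounds, a step that the two limits leave unreadable from compound 1 to compound 3, cannot be read; both of its ends are limits, the limit of > 1070000 nM in this assay, at which 1 of the 3 values shown sits, and (the limit of > 822000 nM in this assay, at which 1 of the 3 values shown sits).

Compound 4 `CC1(C)[C@@H]2CC[C@@]1(C)/C(=N/NC(=O)c1ccco1)C2` differs from compound 3 in one place: furan-2-yl in place of 4-bromophenyl on a carbonyl carbon. Among the measured compounds shown here, no measured step bears on this change, and the only step available gives neither size nor direction. The expectation is that compound 4, like compound 3, sits at the limit in this assay, the estimated step that the limit leaves unreadable from compound 3 to compound 4 being none beyond the scatter. For compound 4 the estimated half-maximal cytotoxic concentration in this assay is 900000 nM, with a range from 300000 nM to 2500000 nM.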

Compound 4, half-maximal cytotoxic concentration: 1090000 nM
The estimate for compound 4 lay 1.2-fold (0.08 log units) below the measured number, within the range that was stated.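

Neither the step from compound 3 to compound 4 nor the step from compound 1 to compound 4 can be read in this assay: compound 1 and compound 3 stand at limits, not numbers, and only compound 4 has a number. Still open, on these data alone, is whether trifluoromethyl, 4-bromophenyl and furan-2-yl on a carbonyl carbon differ at all in this assay.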